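Swapping Isopropyl for Cyclopropyl on a Sulfonyl Sulfur

A few compounds are considered here, and "the series" means these few. Any claim that something is new, unique, unknown or untested is made for them only; others in the source may bear on it.

Of the compounds shown here, two built on one shared core have been tested so far in a functional assay on BXPC-3 cells (Homo sapiens) for inhibition, read by MTT assay, with a stated time of 7 days; on this read-out higher numbers stand for weaker inhibition and lower numbers for stronger inhibition. Compound 2 `CC(C)S(=O)(=O)c1ccc(S(=O)(=O)N2CCC[C@@H](C(=O)N3CCC(F)(F)CC3)C2)cc1` gives 50 nM, the lower of the two numbers measured. Compound 1 `O=C([C@@H]1CCCN(S(=O)(=O)c2ccc(S(=O)(=O)N3CC[C@@H](O)C3)cc2)C1)N1CCC(F)(F)CC1` gives 330 nM in this assay. Among the compounds with values here, the single recorded step, a 6.6-fold lower number from compound 1 to compound 2 (0.82 log units; beyond the scatter), replaced a 3-hydroxypyrrolidin-1-yl group with isopropyl on a sulfonyl sulfur, so the change at that position mattered in that case.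

Compound 3 `O=C([C@@H]1CCCN(S(=O)(=O)c2ccc(S(=O)(=O)C3CC3)cc2)C1)N1CCC(F)(F)CC1` has not yet been measured. It differs from compound 2 only by cyclopropyl in place of isopropyl on a sulfonyl sulfur. Within the data shown here, the one measured step touches the same position, but it exchanged a hydroxyl-bearing ring for a plain isopropyl, whereas here two closely related small carbon groups are swapped. That step therefore gives little guidance on direction, and no change beyond the usual scatter is expected from this exchange. Compound 3 is expected to give about 60 nM in this assay, with a likely range from 25 nM to 150 nM. This estimate corresponds to an expected step of a 1.2-fold higher number from compound 2 to compound 3 (0.08 log units; within the scatter).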

Compound 3, half-maximal inhibitory concentration: 129 nM
The estimate for compound 3 lay 2.2-fold (0.33 log units) below the measured number, and the stated range covers the measured number.
By their numbers in this assay, from the lowest: compound 2; then compound 3; then compound 1.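

In this assay even a swap between two small carbon groups on the sulfonyl sulfur is felt at this position (a 2.6-fold higher number from compound 2 to compound 3 (0.41 log units; beyond the scatter)), a step beyond the usual scatter. This is so although isopropyl and cyclopropyl both hold 3 heavy atoms, all carbon, and the visible difference is that cyclopropyl closes a three-membered ring. Within the data shown here, the earlier step showed only that a hydroxyl-bearing ring and a plain isopropyl give different numbers, whereas cyclopropyl now falls clearly between those two groups (a 2.6-fold lower number from compound 1 to compound 3 (0.41 log units; beyond the scatter)), which gives this position a three-member order with isopropyl lowest and 3-hydroxypyrrolidin-1-yl highest; no supporting measurement on these compounds speaks to the reason for that order.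

The compounds shown leave open whether a straight chain such as ethyl or n-propyl, a bulkier branch such as tert-butyl, or a small amine such as dimethylamino on the same sulfur would give a number lower than that of compound 2. They also leave open whether this order of groups would hold on a different core.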